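Working notes: from compound 2 to compound 3

This account rests on a few compounds, and the source may have more. Where it says the series, first, only, none or still open, it means among the compounds named here.

Values so far in an ADME assay on HeLa cells (Homo sapiens) for cytotoxicity, read by MTT assay (a lower number here means a stronger inhibitor, a higher number a weaker inhibitor), are these.
- compound 1 `COc1ccc(C[C@H]2COC(=O)[C@@H]2Cc2ccc(OC(=O)CCC(=O)N3CCCC3)c(OC)c2)cc1OC` gives 201000 nM
- compound 2 `COc1ccc(C[C@H]2COC(=O)[C@@H]2Cc2ccc(OCc3cn(Cc4ccc(F)cc4)nn3)c(OC)c2)cc1OC` gives 198000 nM

Compound 2 at 198000 nM stands level with compound 1 at 201000 nM, the two lying within the scatter of each other. For the measured compounds named here, neither compound separates from the other, and no measured step isolates a single structural change.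

Compound 3 `COc1ccc(-n2cc(COc3ccc(C[C@H]4C(=O)OC[C@@H]4Cc4ccc(OC)c(OC)c4)cc3OC)nn2)cc1` carries 4-methoxyphenyl in place of 4-fluorobenzyl on an aromatic nitrogen and is still unmeasured. Going by the values given here, with no step to draw on, the only guide is the level shared by compound 1 at 201000 nM and compound 2 at 198000 nM in this assay. The expected change is a 1.2-fold lower number from compound 2 to compound 3 (0.07 log units; within the scatter) and so nothing beyond the scatter, with no direction favoured. Compound 3 is estimated at 170000 nM with an expected range of 70000 nM to 350000 nM in this assay.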

Compound 3, half-maximal inhibitory concentration: >= 600000 nM
Compound 3 gave a limit, no number; the forecaster's own chance of this, stated with the estimate: 15%; at least 3.5-fold (0.54 log units) between middle value and limit.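

In this assay, for the compounds shown here, 4-methoxyphenyl in place of 4-fluorobenzyl on an aromatic nitrogen gives an at least 3.0-fold higher number from compound 2 to compound 3 (0.48 log units; beyond the scatter), the first measured step, and it shows that the read-out responds to a change at this position beyond the scatter. Compound 3 gives a limit of the assay, >= 600000 nM, and not a number. The size of the step is therefore fixed on one side only: the limit of >= 600000 nM in this assay, at which 1 of the 3 values shown sits.

The step carries two differences together, fluorine against methoxy and benzyl against phenyl, and the compounds shown do not separate them. Still open, as far as these compounds go, is how 4-fluorophenyl or 4-methoxybenzyl on the same nitrogen would read, and whether a benzyl group bearing an amine there would stay level with compound 2 or follow compound 3.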